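Chloro to Trifluoromethyl: From Compound 1 to Compound 3

The source may report more compounds than this note shows. Statements on the series, on what has been measured and on what is new or still open speak of the compounds shown alone.

Two measured compounds share one core and differ only in the aryl group attached through the urea-like linkage at one end. Compound 1 `O=C(Nc1cccc(-n2cc(-c3ccncc3)c(-c3ccc(Cl)c(O)c3)n2)c1)Nc1ccc(Cl)c(Cl)c1` carries a 3,4-dichlorophenyl there, while compound 2 `O=C(Nc1cccc(-n2cc(-c3ccncc3)c(-c3ccc(Cl)c(O)c3)n2)c1)Nc1cc(C(F)(F)F)cc(C(F)(F)F)c1` carries a different aryl group in the same place. In a functional assay on A498 cells (Homo sapiens) for inhibition, read by sulforhodamine B assay, with a stated time of 48 h (on this read-out lower numbers stand for stronger inhibition of growth and higher numbers for weaker inhibition of growth), compound 1 gives 3170 nM, and compound 2 gives 4330 nM. Compound 1 therefore shows the lower of the two numbers, but the gap to compound 2 lies within the usual scatter, so the two cannot be told apart on this evidence.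

Compound 3 `O=C(Nc1cccc(-n2cc(-c3ccncc3)c(-c3ccc(Cl)c(O)c3)n2)c1)Nc1ccc(Cl)c(C(F)(F)F)c1` has not yet been measured in this assay. It differs from compound 1 in a single place: trifluoromethyl in place of chloro on an aromatic carbon. Among the compounds with values here, no step between two measured compounds is available to show how such a change moves the read-out, and the two known values sit close together. The step from compound 1 to compound 3 is expected to be small, a 1.1-fold higher number from compound 1 to compound 3 (0.06 log units; within the scatter), with no direction beyond the scatter. Compound 3 is estimated at 3600 nM, in a range from 1500 nM to 8500 nM.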

Compound 3, concentration for total growth inhibition: 6900 nM
Compound 3: middle estimate off by 1.9-fold (0.28 log units), on the low side; measured number inside the range.
By their numbers in this assay, from the lowest: compounds 1, 2 and 3 (each within the scatter of the next, the first and the last beyond it).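

Putting trifluoromethyl in place of chloro on this aromatic carbon, ortho to a chloro group, gives a 2.2-fold higher number from compound 1 to compound 3 (0.34 log units; beyond the scatter) in this assay, a modest step but one that lies beyond the scatter. Within the data shown here, this is the first evidence that a single change at this position can move the read-out, which compound 1 alone could not show, and the direction is toward weaker inhibition of growth. The data offer no measured property that would account for this step, so the result records what happened without explaining it.

The step also rests on one pair of compounds, so it is not yet a trend. As far as these compounds go, it remains open whether a methyl, a methoxy or a nitrile on the same carbon would stay close to compound 1 or shift the number as trifluoromethyl does. From the compounds shown here alone, it is equally open whether an amine or a carboxylic acid would be accepted there, and whether the same swap would give a similar step elsewhere on this aromatic ring.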